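Swapping the amine substituent on a sulfamate-bearing benzamide

The compounds below may be only part of what the source reports. "The series", "measured", "known", "first", "only" and "open" are said of these compounds alone.

Compound 1 `CC(C)CCN(CCC(C)C)c1ccc(C(=O)N2CCc3ccc(OS(N)(=O)=O)cc3C2)cc1` gives 90.8%
Compound 2 `CC(C)CCN(CCC(C)C)c1cccc(C(=O)N2CCc3ccc(OS(N)(=O)=O)cc3C2)c1` gives 75.9%

Both numbers come from an assay on HEK293 cells for inhibition of Steryl-sulfatase (Homo sapiens), tested at 1 uM; a lower number here means a weaker effect, a higher number a stronger effect of the compound at the concentration tested. Compound 1 stands highest of the two; its nearest neighbour, compound 2, lies lower by a gap beyond the usual scatter. Compound 3 `CCCN(Cc1ccccc1)c1ccc(C(=O)N2CCc3ccc(OS(N)(=O)=O)cc3C2)cc1` has not yet been measured. It differs from compound 1 in one place: benzyl(propyl)amino in place of diisopentylamino on an aromatic carbon. For the measured compounds named here, no measured pair shows this change, so the direction rests on expectation alone: a modest decrease is expected, a number 10.8 percentage points lower from compound 1 to compound 3 (beyond the scatter), of a size close to the scatter. Compound 3 is therefore estimated at 80%, expected to fall between 55% and 95%.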

Compound 3, a percentage reported as inhibition, at one concentration (the size of the read-out at that concentration, not a potency): 94.3%
For compound 3 the middle estimate is 14.3 percentage points below the measured one; measured number inside the range.
By their numbers in this assay, from the lowest: compound 2; then compounds 1 and 3 (each within the scatter of the next).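

In this assay, benzyl(propyl)amino in place of diisopentylamino gives a number 3.5 percentage points higher from compound 1 to compound 3 (within the scatter). At this position, para to a large group, the read-out therefore holds when a six-membered aromatic ring enters the substituent and the two branched chains leave, at the same count of heavy atoms. Nothing available explains this tolerance. The compounds shown leave open whether a smaller dimethylamino group or a piperidine ring would hold the read-out here. They also leave open whether benzyl(propyl)amino would fare the same at the ring position carried by compound 2.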